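The source may report more compounds than this note shows. Statements on the series, on what has been measured and on what is new or still open speak of the compounds shown alone.

Measured so far in a functional assay on DLD-1 cells (Homo sapiens) for antiproliferative activity, read by CellTiter-Glo, with a stated time of 72 h; a lower number here means a stronger inhibitor, a higher number a weaker inhibitor:
compound 1 `CC1CCN(C2CCN(S(=O)(=O)c3cccnc3Cl)CC2)CC1`; compound 1 gives > 5000 nM.
compound 2 `CC1CCN(C2CCN(S(=O)(=O)c3cc(F)c(Br)c(F)c3)CC2)CC1`; compound 2 gives 107 nM.
compound 3 `CC1CCN(C2CCN(S(=O)(=O)c3ccc(Br)cc3OC(F)(F)F)CC2)CC1`; compound 3 gives 5 nM.

Going by the values given here, compound 1 stands apart from the other two: its result in this assay is a limit and not a number, and it is the one compound sitting at the limit of > 5000 nM in this assay, at which 1 of the 3 values shown sits. Compounds 2 and 3 both give numbers, and of these two compound 3 shows the lower one.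

Compound 4 `CC1CCN(C2CCN(S(=O)(=O)c3cc(Cl)cc(Cl)c3)CC2)CC1` has not yet been measured in this assay. It differs from compound 1 by 3,5-dichlorophenyl in place of 2-chloropyridin-3-yl on a sulfonyl sulfur. Among the compounds with values here, no step between two measured compounds carries this change, so its size cannot be read off directly; compounds 2 and 3, which also carry a halogen-bearing carbon-only ring on the sulfonyl sulfur, both fall inside the measurable range. Compound 4 is therefore expected to give a number rather than a limit, and the step this estimate means is expected to be an at least 33-fold lower number from compound 1 to compound 4 (1.52 log units; beyond the scatter). Compound 4 is expected to give about 150 nM, with the likely range running from 30 nM to 800 nM.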

Compound 4, half-maximal inhibitory concentration: 3400 nM
Compound 4: middle estimate off by 23-fold (1.36 log units), on the low side; the whole stated range lies below it.
By their numbers in this assay, from the lowest: compound 3; then compound 2; then compound 4. At a limit, above all of these: compound 1.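

In this assay compound 4 gives a number, so 3,5-dichlorophenyl in place of 2-chloropyridin-3-yl on a sulfonyl sulfur reaches the measurable range, and the change reads as an at least 1.4-fold lower number from compound 1 to compound 4 (0.16 log units; that floor lies within the scatter). The result for compound 1 remains a limit and not a number: the limit of > 5000 nM in this assay, at which 1 of the 4 values shown sits. A chlorine-bearing carbon-only ring on the sulfonyl sulfur therefore does not by itself bring a low number: compound 4 gives 3400 nM, while compound 2 gives 107 nM and compound 3 gives 5 nM.

The compounds shown do not tell which feature of the ring separates compound 4 from compound 2 and compound 3, whose rings differ from it in several groups at once. Also open, from the compounds shown here alone, is how a ring carrying a nitrile or a methoxy group would read in this assay.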